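Changing the side chain of compound 3

The source may hold more compounds than are shown below. What is called first, only, known or untested is meant among the compounds shown, and "the series" means these compounds.

In a functional assay (aorta) with Rattus norvegicus as the target (on this read-out lower numbers stand for an effect already at smaller amounts and higher numbers for an effect only at larger amounts of compound), compound 3 `COc1ccc(-c2nc(CNC(=O)CSC)sc2-c2ccc(OC)cc2)cc1` gives 6 uM. Compound 2 `COc1ccc(-c2nc(CNC(C)=O)sc2-c2ccc(OC)cc2)cc1` gives 8.1 uM. The gap is a 1.4-fold lower number from compound 2 to compound 3 (0.13 log units; within the scatter), so the two stand level. Compound 1 `COc1ccc(-c2nc(/N=C(\N)NC3CCCCC3)sc2-c2ccc(OC)cc2)cc1` reads > 100 uM, which is a limit of the assay and not a number. Compound 4 `COc1ccc(-c2nc(C(=O)N=C(N)N)sc2-c2ccc(OC)cc2)cc1` replaces the ((((methylsulfanyl)methyl)carbonyl)amino)methyl group: a group of 6 heavy atoms (2 carbon, 3 nitrogen, 1 oxygen; no ring) in place of a group of 7 heavy atoms (4 carbon, 1 nitrogen, 1 oxygen, 1 sulfur; no ring), on an aromatic carbon. Two large steps bear on this change: an at least 12-fold lower number from compound 1 to compound 2 (1.09 log units; beyond the scatter) and an at least 16-fold lower number from compound 1 to compound 3 (1.22 log units; beyond the scatter). Both start from the measured group that looks most like the entering one, so a move toward higher numbers is expected in this assay, though the resemblance is only partial. The expected step is a 5.0-fold higher number from compound 3 to compound 4 (0.70 log units; beyond the scatter). For compound 4 the estimated value is 30 uM, with an expected range from 6 uM to 100 uM.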

Compound 4, concentration for half-maximal effect: > 100 uM
Compound 4 was reported as a limit (the forecaster's own chance of this, stated with the estimate: 30%); middle value at least 3.3-fold (0.52 log units) away from the limit.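

The earlier large steps all came from compound 1, whose group carries a six-membered ring of carbon, but the entering group of compound 4 has no ring and still gives an at least 16-fold higher number from compound 3 to compound 4 (1.22 log units; beyond the scatter) and an at least 12-fold higher number from compound 2 to compound 4 (1.09 log units; beyond the scatter). So in this assay a ring in this group is not needed for a step of this size on this aromatic carbon. The step between compound 1 and compound 4 cannot be read, as both values are limits of the assay: the limit of > 100 uM in this assay, at which 2 of the 4 values shown sit.

Going by these compounds, how far past its limit compound 4 lies stays unknown. On these data alone, whether a simple amine or a carboxylic acid on this carbon would stand with compound 2 and compound 3 or with compound 4 also stays open.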